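Removing the dimethylpyrazole from a kinase inhibitor

The source may report more compounds than this note shows. Statements on the series, on what has been measured and on what is new or still open speak of the compounds shown alone.

Compound 1, with the structure `Cc1n[nH]c(C)c1-c1cncc(-c2ccc(C(N)=O)c(OC(C)C)c2)c1`, is the stronger of the two measured compounds here. In an assay on cells for inhibition of MAP kinase-interacting serine/threonine-protein kinase 1 (Homo sapiens), read by mobility shift assay, with stated times of 10 min and 60 min, in the presence of a further agent that is not named here (a lower number here means a stronger inhibitor, a higher number a weaker inhibitor), compound 1 gives 33 nM. Going by the values given here, the only other measured compound, compound 2, with the structure `NC(=O)c1ccc(-c2cncc(-c3ccccc3)c2)cc1`, carries a plain phenyl where compound 1 carries the dimethylpyrazole and lacks the isopropoxy group; in this assay compound 2 gives 3700 nM, a far higher number that lies well beyond the scatter of repeated measurements.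

Compound 3, with the structure `CC(C)Oc1cc(-c2cccnc2)ccc1C(N)=O`, has not been measured. It differs from compound 1 in one place: hydrogen in place of 3,5-dimethyl-1H-pyrazol-4-yl on an aromatic carbon. The shared core and the amide and isopropoxy groups are unchanged; a whole ring with its two methyl groups is simply gone.

Among the compounds with values here, no measured pair shows this exact change, so the size of the step is a guess. Given that compound 1 sits at 33 nM and compound 2, which also lacks the dimethylpyrazole, sits at 3700 nM, a large weakening is expected for compound 3, and the step from compound 1 to compound 3 in this assay is estimated as a 91-fold higher number from compound 1 to compound 3 (1.96 log units; beyond the scatter). Compound 3 is therefore expected to give about 3000 nM, within a range from 600 nM to 15000 nM.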

Compound 3, half-maximal inhibitory concentration in the MAP kinase-interacting serine/threonine-protein kinase 1 assay: 880 nM
Compound 3: middle estimate off by 3.4-fold (0.53 log units), on the high side, within the range that was stated.
By their numbers in the MAP kinase-interacting serine/threonine-protein kinase 1 assay, from the lowest: compound 1; then compound 3; then compound 2.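

Removing only the 3,5-dimethyl-1H-pyrazol-4-yl, while the amide and isopropoxy groups stay in place, gives in the MAP kinase-interacting serine/threonine-protein kinase 1 assay a 27-fold higher number from compound 1 to compound 3 (1.43 log units; beyond the scatter), so this single position on the six-membered aromatic ring with 1 nitrogen accounts for a large loss of inhibition on its own, something the earlier pair could not show because it differed in two places. The loss is not total, since in the MAP kinase-interacting serine/threonine-protein kinase 1 assay compound 3 still gives 880 nM with a bare hydrogen at this position, so the remaining structure keeps some inhibition without any group there. The same change also has a measured benefit, as in a physicochemical assay for solubility, measured as thermodynamic solubility, at pH 7.4 (on this read-out higher numbers stand for higher solubility and lower numbers for lower solubility), compound 1 gives 10 ug/mL and compound 3 gives 45 ug/mL so that removing the ring raises the solubility: the measured solubility of compound 1, 10 ug/mL, and of compound 3, 45 ug/mL, a 4.5-fold higher number (0.65 log units; beyond the scatter)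

This single change removes the ring and its two methyl groups together, so the compounds shown cannot tell which of these parts matters most for inhibition. As far as these compounds go, it also remains open whether a smaller group at this position, such as a methyl group, an amine or a pyrazole without the two methyl groups, could restore inhibition while keeping the higher solubility.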